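Replacing the bromophenyl on the core: compound 3

The source may report more compounds than this note shows. Statements on the series, on what has been measured and on what is new or still open speak of the compounds shown alone.

The study tested two compounds in a functional assay on the whole organism (artery, strain albino) with Rattus norvegicus as the target, with a stated time of 300 min, at a dose of 10 mg/kg by the oral route; a higher number here means more inhibition at the dose given (going by the name of the read-out), a lower number less inhibition. Compound 1 `CC1=C(C(=O)Nc2ccc([N+](=O)[O-])cc2)C(c2ccc(Br)cc2)N=C(SCc2ccc(Cl)cc2)N1` gives 37.9% in this assay, and compound 2 `CC1=C(C(=O)Nc2ccc([N+](=O)[O-])cc2)C(c2ccc(Br)cc2)N=C(SCc2ccc(F)cc2)N1` gives 34.4%. Among the measured compounds shown here, the only step between measured compounds, a number 3.5 percentage points lower from compound 1 to compound 2 (within the scatter), is a change of fluoro in place of chloro on an aromatic carbon, and it lies within the scatter. For the measured compounds named here, compound 2 therefore stands on a number that is indistinguishable from that of compound 1, the only other measured compound, so neither can be called stronger or weaker.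

Compound 3 `CC1=C(C(=O)Nc2ccc([N+](=O)[O-])cc2)C(c2cccc([N+](=O)[O-])c2)N=C(SCc2ccc(F)cc2)N1` has not been measured in this assay. It differs from compound 2 as follows: 3-nitrophenyl in place of 4-bromophenyl on a saturated ring carbon. Going by the values given here, no measured step touches the group on the saturated ring carbon; the one step on record concerns the benzyl part of the sulfanyl group, so it does not bear on this change. Among the compounds with values here, with no step to draw on, the account can only expect the number for compound 3 to stay close to that of compound 2, with a wide range. The estimate for compound 3 in this assay is 35%, with a range from 18% to 52%. This corresponds to an expected step of a number 0.6 percentage points higher from compound 2 to compound 3 (within the scatter).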

Compound 3, a percentage reported as inhibition, in the whole organism at one dose (the size of the read-out at that dose, not a potency): 27.2%
The estimate for compound 3 lay 7.8 percentage points above the measured number; low and high end bracket the measured number.
By their numbers in this assay, from the lowest: compounds 3, 2 and 1 (each within the scatter of the next, the first and the last beyond it).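

In this assay, the first change read at the saturated ring carbon next to the ring nitrogen gives a number 7.2 percentage points lower from compound 2 to compound 3 (within the scatter), so 3-nitrophenyl and 4-bromophenyl cannot be told apart at this position at the dose given. The step replaces the halogen with a nitro group and also moves the substituent to another place on the phenyl ring, so the compounds shown cannot divide it between these two differences. Nothing measured alongside these numbers accounts for the result at this position.

The compounds shown carry only substituted phenyl rings on this carbon, so it remains open what a plain phenyl, a saturated cyclohexyl or a phenyl ring bearing an amine or a carboxylic acid would give there. Going by these compounds, it is also open whether the exchange of chloro and fluoro on the benzyl part would read the same with 3-nitrophenyl on the shared core as it does with 4-bromophenyl.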